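Estimating compound 4 from three measured side chains

The source may hold more compounds than are shown below. What is called first, only, known or untested is meant among the compounds shown, and "the series" means these compounds.

The three measured compounds in a functional assay on SH-SY5Y cells (Homo sapiens) for cytotoxicity, read by MTT assay, with a stated time of 72 h (on this read-out lower numbers stand for stronger inhibition and higher numbers for weaker inhibition), are these

Compound 1 `CN(C)CCCCCn1c2c(c3ccccc31)C(=O)c1c[n+]([O-])c3ccccc3c1C2=O` gives 370 nM
Compound 2 `CN1CCN(CCCCn2c3c(c4ccccc42)C(=O)c2c[n+]([O-])c4ccccc4c2C3=O)CC1` gives 100 nM
Compound 3 `O=C1c2c[n+]([O-])c3ccccc3c2C(=O)c2c1c1ccccc1n2CCN1CCCC1` gives 520 nM

Compound 3 sits with compound 1 at the upper end of these numbers, and a 1.4-fold higher number from compound 1 to compound 3 (0.15 log units; within the scatter) keeps the two together. Compound 2 stands clearly apart from both.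

The next structure is compound 4 `CCCCN1CCN(CCCCn2c3c(c4ccccc42)C(=O)c2c[n+]([O-])c4ccccc4c2C3=O)CC1` and the change from compound 3 is 2-(4-butylpiperazin-1-yl)ethyl in place of pyrrolidin-1-yl on a saturated chain carbon, two bonds along the chain from an aromatic nitrogen which places 2-(4-butylpiperazin-1-yl)ethyl in place of pyrrolidin-1-yl on a saturated chain carbon, two bonds along the chain from an aromatic nitrogen.

Among the measured compounds shown here, two measured steps bear on this. The closest is a 5.2-fold higher number from compound 2 to compound 3 (0.72 log units; beyond the scatter) in which 2-(4-methylpiperazin-1-yl)ethyl leaves, so it runs opposite to the present change. The other is a 3.7-fold lower number from compound 1 to compound 2 (0.57 log units; beyond the scatter) which also links the lower number to a piperazine. For the measured compounds named here, no compound with a butyl group has been measured, so that part of the change remains open. Compound 2 at 100 nM is therefore the nearest guide. What is expected in this assay is a 4.0-fold lower number from compound 3 to compound 4 (0.60 log units; beyond the scatter) as a modest estimated step toward a lower number. For compound 4 the estimated value is 130 nM with an expected range from 40 nM to 400 nM as its limits.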

Compound 4, half-maximal inhibitory concentration: 6100 nM
Estimate against measurement, compound 4: 47-fold (1.67 log units) below; measured number above the stated range.
By their numbers in this assay, from the lowest: compound 2; then compounds 1 and 3 (each within the scatter of the next); then compound 4.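

In this assay, a piperazine on the saturated chain carbon, two bonds along the chain from an aromatic nitrogen, does not by itself bring a lower number: 2-(4-butylpiperazin-1-yl)ethyl in place of pyrrolidin-1-yl gives a 12-fold higher number from compound 3 to compound 4 (1.07 log units; beyond the scatter), against the direction of a 5.2-fold higher number from compound 2 to compound 3 (0.72 log units; beyond the scatter). The group carried by the piperazine therefore matters greatly, since propyl in place of hydrogen on a saturated chain carbon bound to an amine nitrogen in a ring, which turns the methyl of compound 2 into the butyl of compound 4, gives a 61-fold higher number from compound 2 to compound 4 (1.79 log units; beyond the scatter), the largest step in this set, and 4-butylpiperazin-1-yl in place of (dimethylamino)methyl likewise gives a 16-fold higher number from compound 1 to compound 4 (1.22 log units; beyond the scatter), reversing the drop seen with the methylpiperazine. No measurement shown here offers an explanation for this sharp rise.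

From the compounds shown here alone, with only methyl and butyl on the piperazine, it remains open whether the number climbs gradually or abruptly along that substituent, which ethyl or propyl in the same place could settle. Going by these compounds, it is also open whether a butyl chain ending in a hydroxyl group or an amine would keep the high number of compound 4.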